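Trifluoromethoxyphenyl Sulfoxide Replaces the Pyridyl Group

The compounds below may be only part of what the source reports. "The series", "measured", "known", "first", "only" and "open" are said of these compounds alone.

Three analogues sharing one core have been examined in a functional assay on DU-145 cells (Homo sapiens) for antiproliferative activity; a higher number here means a weaker inhibitor, a lower number a stronger inhibitor. Compound 1 `CC(O)(C[S+]([O-])c1ccc(F)cc1F)C(=O)Nc1ccc([N+](=O)[O-])cc1C(F)(F)F` carries a 2,4-difluorophenyl group on the sulfur; in this assay compound 1 reaches only a limit, > 100000 nM. Compound 2 `CC(O)(C[S+]([O-])c1ccc(C(F)(F)F)cc1)C(=O)Nc1ccc([N+](=O)[O-])cc1C(F)(F)F` carries a 4-(trifluoromethyl)phenyl group there, and in this assay compound 2 gives 36500 nM. Compound 3 `CC(O)(C[S+]([O-])c1ccccn1)C(=O)Nc1ccc([N+](=O)[O-])cc1C(F)(F)F` carries a pyridin-2-yl group on the sulfur; in this assay compound 3 likewise reaches only a limit, > 100000 nM. Compound 3 thus stands with compound 1 at the limit of > 100000 nM in this assay, at which 2 of the 3 values shown sit, while compound 2 sits below it: the step of an at least 2.7-fold lower number from compound 1 to compound 2 (0.43 log units; beyond the scatter), the step of an at least 2.7-fold higher number from compound 2 to compound 3 (0.43 log units; beyond the scatter), and the step that the two limits leave unreadable from compound 1 to compound 3.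

Compound 4 `CC(O)(C[S+]([O-])c1ccccc1OC(F)(F)F)C(=O)Nc1ccc([N+](=O)[O-])cc1C(F)(F)F` differs from compound 3 in one place: 2-(trifluoromethoxy)phenyl in place of pyridin-2-yl on a sulfur. The steps of an at least 2.7-fold higher number from compound 2 to compound 3 (0.43 log units; beyond the scatter) and an at least 2.7-fold lower number from compound 1 to compound 2 (0.43 log units; beyond the scatter) bear on this change, both exchanging one aromatic group on the sulfur for another. Only the trifluoromethyl-bearing aryl gave a number off the limit, so an aryl with a trifluoromethoxy group is expected to move in that direction, by a modest amount at most. Compound 4 is therefore expected to give about 60000 nM, within 20000 nM to 200000 nM. The step of an at least 1.6-fold lower number from compound 3 to compound 4 (0.22 log units; that floor lies within the scatter) is expected to be modest, with a real chance that only a limit is again reported.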

Compound 4, half-maximal inhibitory concentration: 31100 nM
For compound 4 the middle estimate is 1.9-fold (0.29 log units) above the measured one; the measured number falls inside the stated range.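

In this assay, placing 2-(trifluoromethoxy)phenyl on the sulfur in place of pyridin-2-yl gives an at least 3.2-fold lower number from compound 3 to compound 4 (0.50 log units; beyond the scatter), and the change from 2,4-difluorophenyl gives an at least 3.2-fold lower number from compound 1 to compound 4 (0.50 log units; beyond the scatter), so a second aromatic group now yields a number rather than a limit. The remaining comparison gives a 1.2-fold lower number from compound 2 to compound 4 (0.07 log units; within the scatter), which leaves 2-(trifluoromethoxy)phenyl and 4-(trifluoromethyl)phenyl indistinguishable in this assay despite their different names and substituents. Among the four compounds, the two aryl groups bearing a trifluoromethyl or trifluoromethoxy group give numbers, whereas compound 1, though it also carries fluorine, and compound 3 remain limits of the assay: the limit of > 100000 nM in this assay, at which 2 of the 4 values shown sit.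

The compounds shown leave open whether the number depends on the trifluoromethoxy and trifluoromethyl groups themselves, or whether a phenyl group carrying a chlorine, a nitrile or a methoxy group would also leave the limit. They also do not tell whether 4-(trifluoromethoxy)phenyl would match compound 4, or how a sulfone or a thioether in place of the sulfoxide would read in this assay.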